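Inversion at the ring carbon of a demethylated cyclic carbamate

The source may hold more compounds than are shown below. What is called first, only, known or untested is meant among the compounds shown, and "the series" means these compounds.

Compound 3 `C[N+](C)(C)C[C@@H]1CNC(=O)O1` stands at the limit of an assay on CHO cells for displacement of a labelled ligand from muscarinic acetylcholine receptor M5 (Homo sapiens); a higher number here means a weaker inhibitor, a lower number a stronger inhibitor: in this assay compound 3 gives only > 100000 nM, a limit and not a number. Compound 1 `CN1C[C@@H](C[N+](C)(C)C)OC1=O` also sits at a limit, giving > 100000 nM in this assay. Compound 2 `CN1C[C@H](C[N+](C)(C)C)OC1=O` likewise gives only the limit > 100000 nM in this assay. Compound 4 `C[N+](C)(C)C[C@H]1CNC(=O)O1` differs from compound 3 in that (the two compounds have the same atoms and bonds and differ only in configuration as drawn: 1 of 1 stereo elements differ; a stereocentre at a saturated ring carbon is drawn S in compound 3 and R in compound 4). Going by the values given here, the measured step that bears most directly on this change is the one from compound 1 to compound 2, a step that the two limits leave unreadable from compound 1 to compound 2, which is unreadable because the limit of > 100000 nM in this assay, at which 3 of the 3 values shown sit, and the fact that compounds 1 and 2 differ only in the configuration as drawn together leave no number. The step from compound 1 to compound 3, a step that the two limits leave unreadable from compound 1 to compound 3, is unreadable for the same reason. Among the compounds with values here, no measured step therefore points in either direction, and compound 4 is expected to remain at the limit, an expected step of a number no higher from compound 3 to compound 4 (the limit leaves the size open). Compound 4 is estimated at 100000 nM, with a range from 30000 nM to 300000 nM.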

Compound 4, inhibition constant: > 100000 nM
Compound 4: no number, only a limit; the forecaster's own chance of this, stated with the estimate: 85%; the middle value lies on the limit itself.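

In this assay compound 4 gives > 100000 nM as a limit and not a number. Going by these compounds alone, compounds 2 and 3 also stand at limits, so no new step to compound 4 can be read. The compounds shown leave open whether in this assay the ring-carbon configuration or the methyl on the amide-type nitrogen makes any difference.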